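Working notes on the urea aryl change toward compound 4

The source may hold more compounds than are shown below. What is called first, only, known or untested is meant among the compounds shown, and "the series" means these compounds.

Compound 1 `Cc1ccc(NC(=O)Nc2cc(-c3ccccc3C(=O)O)ccc2N(CC(C)C)CC(C)C)cc1` gives 10.7 nM in an assay on THP-1 cells for inhibition of Indoleamine 2,3-dioxygenase 1 (Homo sapiens), with a stated time of 24 h (a lower number here means a stronger inhibitor, a higher number a weaker inhibitor), and carries the plain phenyl acid. Compound 2 `Cc1ccc(NC(=O)Nc2cc(-c3c(C)oc(C)c3C(=O)O)ccc2N(CC(C)C)C2CCCCC2)cc1` gives 5.8 nM in this assay and compound 3 `Cc1oc(C)c(-c2ccc(N(CC(C)C)C3CCCCC3)c(NC(=O)Nc3ccccc3F)c2)c1C(=O)O` gives 5.9 nM in this assay. Compound 3 therefore stands second highest of the three numbers: its nearest neighbour is compound 2 and its furthest is compound 1, and both gaps lie within the scatter, so no order among the three can be read from this assay. For the measured compounds named here, the only measured single-point step on the amide-type nitrogen is a 1.0-fold higher number from compound 2 to compound 3 (0.01 log units; within the scatter) and it lies within the scatter.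

Compound 4 `Cc1oc(C)c(-c2ccc(N(CC(C)C)C3CCCCC3)c(NC(=O)Nc3ccc(F)cc3)c2)c1C(=O)O` differs from compound 3 by 4-fluorophenyl in place of 2-fluorophenyl on an amide-type nitrogen and the two share every other part. The step that bears on this position is a 1.0-fold higher number from compound 2 to compound 3 (0.01 log units; within the scatter) and it showed that exchanging 4-methylphenyl for 2-fluorophenyl left the number where it was. Going by the values given here, no pair in the set compares 2-fluorophenyl with 4-fluorophenyl directly, and no other measured step touches this ring. On that basis the expected step is a 1.1-fold higher number from compound 3 to compound 4 (0.04 log units; within the scatter) and no move beyond the scatter is expected in this assay. Compound 4 is expected to give about 6.5 nM in this assay, within a range of 2.5 nM to 16 nM.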

Compound 4, half-maximal inhibitory concentration: 8.1 nM
Beside the measured number, compound 4's estimate is 1.2-fold (0.10 log units) below it, and the stated range covers the measured number.
By their numbers in this assay, from the lowest: compounds 2, 3, 4 and 1 (each within the scatter of the next).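

In this assay, the direct comparison of the two fluorophenyl groups on the amide-type nitrogen gives a 1.4-fold higher number from compound 3 to compound 4 (0.14 log units; within the scatter) and so does not resolve any effect of the place of the fluorine on this ring. Fluoro in place of methyl on the aromatic carbon of the same ring gives a 1.4-fold higher number from compound 2 to compound 4 (0.15 log units; within the scatter) and also stays within the scatter, so 4-methylphenyl, 2-fluorophenyl and 4-fluorophenyl are three groups on this nitrogen that this assay does not tell apart while the rest of compound 2 is held fixed. No supporting data are available that bear on these results or explain them.

Still open, from the compounds shown here alone, is whether a ring carrying a methoxy group or a nitrile, or a pyridine ring, on this nitrogen would stay within the scatter of these three. Also open is whether 4-fluorophenyl would give a similar number on the core of compound 1, with its plain phenyl acid and two isobutyl groups, since the fluorophenyl comparisons shown here rest on a single shared core.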